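The compounds below may be only part of what the source reports. "The series", "measured", "known", "first", "only" and "open" are said of these compounds alone.

Measured so far:
- Compound 1 `CCCC(NC(=O)c1nccs1)c1cnc(Nc2ccc(C)nc2)c(Cl)c1`: 28.7 nM
- Compound 2 `CCC[C@@H](NC(=O)c1nccs1)c1cnc(Nc2ccc(C)nc2)c(Cl)c1`: 8.2 nM
- Compound 3 `CCC[C@H](NC(=O)c1nccs1)c1cnc(Nc2ccc(C)nc2)c(Cl)c1`: 978 nM

In a functional assay on HEK293 cells for negative allosteric modulation of metabotropic glutamate receptor 5 (Homo sapiens), read by HTRF and inositol phosphate accumulation (on this read-out lower numbers stand for stronger inhibition and higher numbers for weaker inhibition), compound 3 gives the highest number of the three, which means it is the weakest inhibitor of this small set. The steps are a 34-fold higher number from compound 1 to compound 3 (1.53 log units; beyond the scatter) and a 120-fold higher number from compound 2 to compound 3 (2.08 log units; beyond the scatter). Compound 2 and compound 3 share every atom and bond and differ only in the configuration at one saturated chain carbon (the fact that compounds 2 and 3 differ only in the configuration as drawn), so the whole of that large gap goes with the drawn configuration. Compound 1, drawn without a configuration at that centre, sits between them, with a 3.5-fold lower number from compound 1 to compound 2 (0.54 log units; beyond the scatter).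

Compound 4 `Cc1ccc(Nc2ncc([C@@H](NC(=O)c3nccs3)C(C)C)cc2Cl)cn1` keeps the configuration of compound 3 and changes only the chain on that carbon: isopropyl in place of propyl on a saturated chain carbon bound to an amide-type nitrogen and an aromatic carbon. Within the data shown here, none of the measured steps alters this chain; all three concern the configuration alone. Among the measured compounds shown here, there is therefore no measured step that speaks to swapping propyl for isopropyl, and the expectation for compound 4 rests on its sharing the configuration of compound 3, whose value is 978 nM. The expected step is a 1.0-fold higher number from compound 3 to compound 4 (0.01 log units; within the scatter), that is, no change beyond the scatter. Compound 4 is estimated at 1000 nM, with a range from 300 nM to 4000 nM.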

Compound 4, half-maximal inhibitory concentration: 1060 nM
The estimate for compound 4 lay 1.1-fold (0.03 log units) below the measured number, within the range that was stated.
By their numbers in this assay, from the lowest: compound 2; then compound 1; then compounds 3 and 4 (each within the scatter of the next).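

Among these compounds, compound 4 gives the first step in which the chain itself changes on the saturated chain carbon bound to an amide-type nitrogen and an aromatic carbon, rather than the configuration there: in this assay, the result is a 1.1-fold higher number from compound 3 to compound 4 (0.03 log units; within the scatter). Propyl and isopropyl carry the same count of carbons and differ only in how those carbons are joined, so with the configuration of compound 3, rearranging the chain in this way leaves the number within the usual scatter, while the change of configuration alone between compound 2 and compound 3 moved it far beyond that scatter. The facts at hand on these compounds concern configuration only and do not bear on this swap of chains.

The compounds shown leave open whether isopropyl would read the same way in the configuration of compound 2, which with propyl gives 8.2 nM, as a flat step in one configuration need not carry over to the other. They also leave open how a longer chain such as butyl, or a small ring such as cyclopropyl, would read on this carbon in either configuration.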